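A few compounds are considered here, and "the series" means these few. Any claim that something is new, unique, unknown or untested is made for them only; others in the source may bear on it.

Working notes on the series. In a functional assay on HeLa cells (Homo sapiens) for antiproliferative activity, with a stated time of 48 h (on this read-out lower numbers stand for stronger inhibition and higher numbers for weaker inhibition), compound 3 (`Nc1ccc(/C=C/C(=O)c2ccc(F)cc2)cc1`) gives 40000 nM and compound 2 (`Nc1ccc(/C=C/C(=O)c2ccccc2)cc1`) gives 36000 nM as its value, so the two sit level at the high-number end of the three measured compounds. Compound 1 (`C=C(Br)C(=O)Nc1ccc(/C=C/C(=O)c2ccc(Cl)cc2)cc1`) stands well apart at 1600 nM as its value, a much lower number than either of them and, against compound 3, beyond the scatter.

Compound 4 (`Nc1ccc(/C=C/C(=O)c2ccc(Cl)cc2)cc1`) is still unmeasured. The change from compound 3 is chloro in place of fluoro on an aromatic carbon and it amounts to chloro in place of fluoro on an aromatic carbon, para to a large group. Among the measured compounds shown here, the only measured step at that place is a 1.1-fold higher number from compound 2 to compound 3 (0.05 log units; within the scatter) and it lies within the scatter. For the measured compounds named here, compound 1 also carries chloro, but it differs from compound 4 elsewhere too, so it supplies no measured step for this exchange. With that single flat step as the guide, no step beyond the scatter is expected in this assay in either direction. The estimate means a 1.3-fold lower number from compound 3 to compound 4 (0.10 log units; within the scatter) as the expected step, which stays within the scatter. Compound 4 is expected at 32000 nM within an estimated range from 15000 nM to 65000 nM for this measurement.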

Compound 4, half-maximal inhibitory concentration: 43000 nM
Estimate against measurement, compound 4: 1.3-fold (0.13 log units) below; measured number inside the range.
By their numbers in this assay, from the lowest: compound 1; then compounds 2, 3 and 4 (each within the scatter of the next).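

Working notes, continued. In this assay the chloro exchange on the aromatic carbon, para to a large group, gives a 1.1-fold higher number from compound 3 to compound 4 (0.03 log units; within the scatter) and, against the unsubstituted ring, a 1.2-fold higher number from compound 2 to compound 4 (0.08 log units; within the scatter), so hydrogen, fluoro and chloro at this place all sit level while the nitrogen carries hydrogen. The pair of compounds differing at the nitrogen gives the first measured step there, a 27-fold higher number from compound 1 to compound 4 (1.43 log units; beyond the scatter), for hydrogen in place of (1-bromoethenyl)carbonyl, and among the steps shown, the large difference lies at the nitrogen and not at the aromatic carbon. No supporting measurement is available to account for either the level steps or the large one.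

Still open, from the compounds shown here alone, is whether the level response to hydrogen, fluoro and chloro at the aromatic carbon carries over to compounds with (1-bromoethenyl)carbonyl on the nitrogen, where compound 1 stands alone here. Also open, going by these compounds, is how a methoxy group or a carboxylic acid at that aromatic carbon, or a plain acetyl group on the nitrogen, would read in this assay.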